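Indole Piperidines and Compound 4

The compounds below may be only part of what the source reports. "The series", "measured", "known", "first", "only" and "open" are said of these compounds alone.

Compounds with measurements:
compound 1, `CC(=O)Nc1ccc(CNC2CCN(CCCc3c[nH]c4ccc(-n5cnnc5)cc34)CC2)cc1` — 3 nM
compound 2, `CC(C)=CCN(C)C1CCN(CCCc2c[nH]c3ccc(-n4cnnc4)cc23)CC1` — 0.5 nM
compound 3, `CNS(=O)(=O)Cc1ccc2[nH]cc(CCCN3CCC(N[C@H](C)c4ccccc4)CC3)c2c1` — 43 nM

In an assay on CHO cells for displacement of a labelled ligand from 5-hydroxytryptamine receptor 1D (Homo sapiens) (on this read-out lower numbers stand for stronger inhibition and higher numbers for weaker inhibition), compound 2 gives 0.5 nM and stands lowest of the three numbers. Its nearest neighbour is compound 1, which in this assay gives 3 nM, a gap beyond the scatter; compound 3, which in this assay gives 43 nM, lies furthest away, also beyond the scatter.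

Compound 4, `C[C@H](NCC1CCN(CCCc2c[nH]c3ccc(-n4cnnc4)cc23)CC1)c1ccccc1`, has not yet been measured. It differs from compound 2 in one place: ((1-phenylethyl)amino)methyl in place of methyl(3-methylbut-2-en-1-yl)amino on a saturated ring carbon. Compound 3 carries the 1-phenylethyl amine on a different core and is the weakest of the three, while compound 1, with a basic amine and an aromatic ring on the same core as compound 2, sits much closer to it. Compound 4 is expected to lose some potency relative to compound 2, a step of a 12-fold higher number from compound 2 to compound 4 (1.08 log units; beyond the scatter) in this assay being the estimate, beyond the scatter. Compound 4 is therefore expected to give 6 nM in this assay, within a range of 1.5 nM to 25 nM.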

Compound 4, half-maximal inhibitory concentration: 4.4 nM
For compound 4 the middle estimate is 1.4-fold (0.13 log units) above the measured one; the range from low to high includes it.
By their numbers in this assay, from the lowest: compound 2; then compounds 1 and 4 (each within the scatter of the next); then compound 3.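

In this assay, among these compounds, the exchange of methyl(3-methylbut-2-en-1-yl)amino for ((1-phenylethyl)amino)methyl on this saturated ring carbon brings an 8.8-fold higher number from compound 2 to compound 4 (0.94 log units; beyond the scatter), the first step on the shared core in which only one place differs. The position thus accepts a larger group carrying a six-membered aromatic ring of carbon only, at a modest cost, and compound 4 still gives 4.4 nM. Nothing measured here accounts for the size of this step.

The step changes the aromatic ring, the hydrogen-bond donor and the defined stereocentre together, so the compounds shown leave open which of these matters. Going by these compounds, it also remains open how a plain benzylamino group, the opposite stereocentre or a carboxylic acid would fare at this ring carbon.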